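Aryl amide swap on a cyclopropane dicarboxamide linker

This account rests on a few compounds, and the source may have more. Where it says the series, first, only, none or still open, it means among the compounds named here.

Measured compounds:
compound 1 `CN(C)C(=O)c1cc2cnc(Nc3ccc(NC(=O)C4(C(=O)Nc5cccc(O)c5)CC4)cc3)nc2n1C1CCCC1`: 57%
compound 2 `CN(C)C(=O)c1cc2cnc(Nc3ccc(NC(=O)C4(C(=O)Nc5ccc(F)cc5)CC4)cc3F)nc2n1C1CCCC1`: 6.2%

In a functional assay on HeLa cells (Homo sapiens) for inhibition, read by CCK-8 assay, with a stated time of 72 h, tested at 1 uM (a lower number here means less inhibition of growth, a higher number more inhibition of growth at the concentration tested), compound 1 gives 57%, the higher of the two numbers seen. Compound 2 gives 6.2% in this assay, a gap that lies beyond the scatter; compound 2 differs from compound 1 in more than one place, so its lower value cannot be tied to a single change.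

Compound 3 `CN(C)C(=O)c1cc2cnc(Nc3ccc(NC(=O)C4(C(=O)Nc5ccc(Cl)c(C(F)(F)F)c5)CC4)cc3)nc2n1C1CCCC1` has not been measured. It differs from compound 1 in one place: 4-chloro-3-(trifluoromethyl)phenyl in place of 3-hydroxyphenyl on an amide-type nitrogen. For the measured compounds named here, no measured pair isolates this change, so the step can only be judged from the two values shown. Because compound 2, which also lacks the hydroxyl-bearing ring, gives 6.2%, the step is expected to run downward and to be of moderate size, but with wide uncertainty. The step from compound 1 to compound 3 is estimated at a number 22 percentage points lower from compound 1 to compound 3 (beyond the scatter). Compound 3 is therefore expected to give about 35%, within a range of 8% to 65%.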

Compound 3, percent growth inhibition at one concentration: 16.5%
For compound 3 the middle estimate is 18.5 percentage points above the measured one, and the stated range covers the measured number.
By their numbers in this assay, from the lowest: compound 2; then compound 3; then compound 1.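

Exchanging 3-hydroxyphenyl for 4-chloro-3-(trifluoromethyl)phenyl on the amide-type nitrogen gives a number 40.5 percentage points lower from compound 1 to compound 3 (beyond the scatter) in this assay, with the rest of the molecule unchanged. For the compounds shown here, this is the first comparison in which a loss of growth inhibition can be tied to a single place, showing that the group on this nitrogen alone can change the read-out by a large margin. The change removes the hydroxyl and adds both chloro and trifluoromethyl groups, and no measurement here explains the drop.

The compounds shown leave open whether the step follows from losing the hydroxyl or from gaining either of the two new groups. As far as these compounds go, how a plain phenyl, 3-methoxyphenyl or 3-aminophenyl ring on this nitrogen would read in this assay also remains open.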